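The source may hold more compounds than are shown below. What is called first, only, known or untested is meant among the compounds shown, and "the series" means these compounds.

Measured so far in a physicochemical assay for solubility, in phosphate buffer, measured as kinetic solubility, with a stated time of 24 h, at pH 6.5; on this read-out higher numbers stand for higher solubility and lower numbers for lower solubility:

- compound 1 `Cc1ccc(NC(=O)c2cc(Oc3ccc(S(C)(=O)=O)cc3)cc(OC(C)C)c2)nc1`: 1400 nM
- compound 2 `CC(C)Oc1cc(Oc2ccc(S(C)(=O)=O)cc2)cc(-c2nccc(=O)[nH]2)c1`: 25000 nM

Compound 2 stands highest of these two numbers. Among the compounds with values here, the gap is an 18-fold higher number from compound 1 to compound 2 (1.25 log units; beyond the scatter), the only measured step.

Compound 3 `CNS(=O)(=O)c1ccc(Oc2cc(OC(C)C)cc(-c3nccc(=O)[nH]3)c2)cc1` departs from compound 2 at a single place: methylamino in place of methyl on a sulfonyl sulfur. Methylamino stands in place of methyl on a sulfonyl sulfur, so methylsulfonyl becomes methylsulfamoyl, and the rest of the structure stays the same.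

Within the data shown here, the one measured step bears on this change only weakly. That large step, an 18-fold higher number from compound 1 to compound 2 (1.25 log units; beyond the scatter), replaced a group on an aromatic carbon and left the sulfonyl sulfur untouched. Among the measured compounds shown here, it shows how far this assay can move, but no measured pair tests a change at the sulfonyl sulfur, so the data give no direction for it. The expected outcome is therefore a 1.3-fold lower number from compound 2 to compound 3 (0.10 log units; within the scatter), with no shift beyond the scatter anticipated, though the uncertainty is wide. For compound 3 the estimated value is 20000 nM, with an expected range of 6000 nM to 50000 nM.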

Compound 3, solubility: 117000 nM
The estimate for compound 3 lay 5.9-fold (0.77 log units) below the measured number, outside the stated range (above it).
By their numbers in this assay, from the lowest: compound 1; then compound 2; then compound 3.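

Methylamino in place of methyl on a sulfonyl sulfur gives, in this assay, a 4.7-fold higher number from compound 2 to compound 3 (0.67 log units; beyond the scatter). The earlier compounds shown here had tested only a replacement on an aromatic carbon, in an 18-fold higher number from compound 1 to compound 2 (1.25 log units; beyond the scatter); this result shows that the sulfonyl sulfur is also a place where a single small change, methylsulfonyl to methylsulfamoyl, moves the number beyond the scatter, although by less than that earlier step. No measurement offered here explains why the number moved at this position.

With a single replacement shown at this place, it remains open whether the step follows the nitrogen itself, the hydrogen-bond donor that enters with it, or the methyl group on that nitrogen, and an unsubstituted amino group, a dimethylamino group or a longer chain such as ethylamino would help separate these readings. As far as these compounds go, it also remains open whether methylsulfonyl to methylsulfamoyl would give a step of similar size and direction on the core of compound 1, which carries the other group on the aromatic carbon.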